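The source may hold more compounds than are shown below. What is called first, only, known or untested is meant among the compounds shown, and "the series" means these compounds.

Working notes on the series. The shared core is that of compound 1 `O=C(O)CCc1cccc2c1B(O)OC2`. In a functional assay on HCT-116 cells (Homo sapiens) for antiproliferative activity, read by MTT assay, with a stated time of 72 h (a higher number here means a weaker inhibitor, a lower number a stronger inhibitor), compound 1 gives > 100000 nM, which is a limit of the assay and not a number. Compound 2 `O=C(CCc1cccc2c1B(O)OC2)NC1CCCCC1` carries cyclohexylamino in place of hydroxy on a carbonyl carbon. In this assay compound 2 gives > 100000 nM, again a limit. Compound 3 `O=C(CCc1cccc2c1B(O)OC2)Nc1nccs1` carries (1,3-thiazol-2-yl)amino in place of hydroxy on a carbonyl carbon. In this assay compound 3 gives > 100000 nM, also a limit. Compound 3 thus stands at the limit of > 100000 nM in this assay, at which 3 of the 3 values shown sit, as do the other two measured compounds. The steps a step that the two limits leave unreadable from compound 1 to compound 2, a step that the two limits leave unreadable from compound 1 to compound 3 and a step that the two limits leave unreadable from compound 2 to compound 3 all run between two limits and give no readable size. Compound 4 `Cc1ccc(NC(=O)CCc2cccc3c2B(O)OC3)cc1` differs from compound 3 by 4-methylphenyl in place of 1,3-thiazol-2-yl on an amide-type nitrogen. The last of the measured steps, an exchange on the same amide-type nitrogen, bears most directly on this change, yet its size is unreadable, so no direction beyond the scatter can be expected. Compound 4 is expected at 150000 nM, in the range 50000 nM to 500000 nM. The expected step that the limit leaves unreadable from compound 3 to compound 4 is nothing beyond the scatter, most likely another limit.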

Compound 4, half-maximal inhibitory concentration: 4500 nM
Compound 4: the middle estimate sits 33-fold (1.52 log units) above what was measured; measured number outside the range, below it.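

Going by these compounds alone, the change on this amide-type nitrogen is the first with a readable size in this assay: it gives an at least 22-fold lower number from compound 3 to compound 4 (1.34 log units; beyond the scatter), and the exchange for cyclohexyl gives an at least 22-fold lower number from compound 2 to compound 4 (1.34 log units; beyond the scatter). An aromatic ring on this nitrogen is not enough by itself, since compound 3 also carries one and stays at a limit, while the steps among the three earlier compounds cannot be read. Of the groups on this nitrogen, only 4-methylphenyl gives a number rather than a limit: the limit of > 100000 nM in this assay, at which 3 of the 4 values shown sit.

Going by these compounds, whether the gain depends on the methyl group or on the carbon-only six-membered ring stays open, and a plain phenyl on the same nitrogen would separate the two. On these data alone, whether a benzyl group or a longer chain keeps the gain also stays open.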